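Prenyl Ether in Place of Methyl Ether: Cytotoxicity Outlook

The compounds below may be only part of what the source reports. "The series", "measured", "known", "first", "only" and "open" are said of these compounds alone.

Compound 1 `CCC1(Cc2ccccc2)OS(=O)(=O)C=C1OC` in an ADME assay on HEL cells (Homo sapiens) for cytotoxicity, with a stated time of 3 days; on this read-out lower numbers stand for higher toxicity in this test and higher numbers for lower toxicity in this test: > 200000 nM
Compound 2 `CCC1(Cc2ccccc2)OS(=O)(=O)C=C1OS(=O)(=O)c1ccc(C)cc1` in this assay: 109000 nM
Compound 3 `CC(C)CC1(Cc2ccccc2)OS(=O)(=O)C=C1OCc1ccccc1` in this assay: 102000 nM

The value for compound 1 is a limit of this assay, not a number, as shown by the limit of > 200000 nM in this assay, at which 1 of the 3 values shown sits. Compound 4 `CCC1(Cc2ccccc2)OS(=O)(=O)C=C1OCC=C(C)C` differs from compound 1 in one place: 2-methylprop-1-en-1-yl in place of hydrogen on a saturated chain carbon bound to an oxygen on an unsaturated carbon. For the measured compounds named here, no step between measured compounds is known, so the expected move in this assay rests on the shared core alone. Compound 2 gives 109000 nM and compound 3 gives 102000 nM, both carrying larger groups on the same oxygen, so a similar region is expected for compound 4. Compound 4 is expected to sit at 120000 nM, between 50000 nM and 250000 nM, an expected step of an at least 1.6-fold lower number from compound 1 to compound 4 (0.22 log units; that floor lies within the scatter) whose size is uncertain since compound 1 holds only a limit.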

Compound 4, half-maximal cytotoxic concentration: 112000 nM
Beside the measured number, compound 4's estimate is 1.1-fold (0.03 log units) above it; the measured number falls inside the stated range.
By their numbers in this assay, from the lowest: compounds 3, 2 and 4 (each within the scatter of the next). At a limit, above all of these: compound 1.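

For the compounds shown here, compound 4 gives the first reading of a change at this position, the saturated chain carbon bound to an oxygen on an unsaturated carbon: in this assay, 2-methylprop-1-en-1-yl in place of hydrogen gives an at least 1.7-fold lower number from compound 1 to compound 4 (0.25 log units; that floor lies within the scatter). From the compounds shown here alone, compound 1 holds only a limit in this assay: the limit of > 200000 nM in this assay, at which 1 of the 4 values shown sits. The true size of the step stays unknown beyond that floor.

The compounds shown leave open how an amine or a carboxylic acid in place of 2-methylprop-1-en-1-yl would read in this assay. Going by these compounds, whether a saturated 3-methylbutyl group would read the same also stays open.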